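Cyclohexyl to methyl on the ether oxygen: expected drop in lipophilicity

This account rests on a few compounds, and the source may have more. Where it says the series, first, only, none or still open, it means among the compounds named here.

Measured compounds:
compound 1 `CCc1ccc(N(CC(C)C)S(=O)(=O)c2ccc3c(c2)C(OC2CCCCC2)CC(C2CCOCC2)O3)cc1` — 6.28
compound 2 `CC(C)CN(c1ccc(F)cc1)S(=O)(=O)c1ccc2c(c1)C(O)CC(C1CCOCC1)O2` — 3.39
compound 3 `CCc1ccc(N(CC(C)C)S(=O)(=O)c2ccc3c(c2)C(O)CC(CC2CCOCC2)O3)cc1` — 4.44

In a physicochemical assay for lipophilicity, at pH 7.4 (a lower number here means a more polar compound, a higher number a more lipophilic compound), compound 1 gives 6.28, the highest of the three numbers. Compound 3 is nearest to it, and compound 2 lies furthest off; both differences go well beyond the scatter. Compound 4 `CCc1ccc(N(CC(C)C)S(=O)(=O)c2ccc3c(c2)C(OC)CC(C2CCOCC2)O3)cc1` is not yet measured. It differs from compound 1 in one place: methyl in place of cyclohexyl on an oxygen on a saturated carbon. Nothing else in the shared core changes. Among the compounds with values here, since no pair of measured compounds differs in just one place, the size of this step has to be estimated rather than read off. In this assay the step is expected to be large and downward, a number 2.08 log units lower from compound 1 to compound 4 (beyond the scatter). Compound 4 is therefore expected to give about 4.2, within a range from 3.6 to 4.8.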

Compound 4, distribution coefficient: 4.69
Compound 4: the middle estimate sits 0.49 log units below what was measured; the range from low to high includes it.
By their numbers in this assay, from the lowest: compound 2; then compounds 3 and 4 (each within the scatter of the next); then compound 1.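

Methyl in place of cyclohexyl on an oxygen on a saturated carbon now gives a directly read step at this position: in this assay it is a number 1.59 log units lower from compound 1 to compound 4 (beyond the scatter). The oxygen stays in place in both compounds, so the step reflects only the change in the group attached to it. Nothing measured here accounts for the size of this step.

The compounds shown leave open where an ethyl group or a longer chain on the same oxygen would fall, and what a carboxylic acid at the end of such a chain would give.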